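Working notes: cytotoxicity limits and a trifluoromethyl analogue

This account rests on a few compounds, and the source may have more. Where it says the series, first, only, none or still open, it means among the compounds named here.

Compound 1, `Cn1c(CO[C@@H]2COc3nc([N+](=O)[O-])cn3C2)cnc1-c1ccc(OC(F)(F)F)cc1`, in an ADME assay on Vero cells (Chlorocebus sabaeus) for cytotoxicity, with a stated time of 72 h (a lower number here means a stronger inhibitor, a higher number a weaker inhibitor), gives > 128000 nM, a limit of the assay.
Compound 2, `COc1ccc(-c2cc(CO[C@@H]3COc4nc([N+](=O)[O-])cn4C3)on2)cc1F`, in this assay gives > 128000 nM, a limit of the assay.
Compound 3, `O=[N+]([O-])c1cn2c(n1)OC[C@@H](OCc1cnn(-c3ccccc3)n1)C2`, in this assay gives > 128000 nM, a limit of the assay.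

Compound 3 therefore stands where every measured member of the set stands: at the limit of > 128000 nM in this assay, at which 3 of the 3 values shown sit. No numeric value is known for any of the three, so no step between measured compounds can be given, and nothing separates compound 3 from compound 1 or compound 2 on the numbers shown.

Compound 4, `O=[N+]([O-])c1cn2c(n1)OC[C@@H](OCc1cnn(-c3ccc(C(F)(F)F)cc3)n1)C2`, is the next compound to be measured in this assay. It differs from compound 3 by trifluoromethyl in place of hydrogen on an aromatic carbon.

With all three measured values sitting at the same limit, the expectation for the step from compound 3 to compound 4 is a step that the limit leaves unreadable from compound 3 to compound 4, none beyond the usual scatter. Compound 4 is estimated to give 150000 nM in this assay, with a range from 64000 nM to 400000 nM, and the assay is expected most likely to report only a limit again.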

Compound 4, half-maximal inhibitory concentration: > 128000 nM
Compound 4: only a limit was reported (the forecaster's own chance of this, stated with the estimate: 85%); the middle value does not contradict the limit.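

No step can be read from compound 3 to compound 4, since both give only a limit in this assay: the limit of > 128000 nM in this assay, at which 4 of the 4 values shown sit.

The compounds shown leave open whether trifluoromethyl in place of hydrogen on an aromatic carbon shifts the read-out at all, and how any of these compounds rank against one another in this assay.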